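A few compounds are considered here, and "the series" means these few. Any claim that something is new, unique, unknown or untested is made for them only; others in the source may bear on it.

In a functional assay on HepG2 cells (Homo sapiens) for cytotoxicity, read by MTT assay, with a stated time of 24 h (on this read-out higher numbers stand for weaker inhibition and lower numbers for stronger inhibition), compound 1 `CN1C/C(=C\c2cccc([N+](=O)[O-])c2)C(=O)/C(=C/c2ccccc2F)C1` gives 1080 nM and lies within the scatter of compound 2 `COc1cc(/C=C2\CN(C)C/C(=C\c3cc(OC)c(OC)c(OC)c3)C2=O)cc(OC)c1` at 890 nM while compound 3 `COc1cc(/C=C2\CN(C)C/C(=C\c3ccc(Cl)cc3Cl)C2=O)cc(OC)c1OC` reads 8800 nM and stands clearly higher than both. Compound 4 `CN1C/C(=C\c2ccc(Cl)cc2)C(=O)/C(=C/c2cccc([N+](=O)[O-])c2)C1` has not yet been measured. It differs from compound 1 by a single swap, 4-chlorophenyl in place of 2-fluorophenyl on a double-bonded chain carbon bound to a double-bonded ring carbon in which 4-chlorophenyl takes the place of 2-fluorophenyl on a double-bonded chain carbon bound to a double-bonded ring carbon. Among the measured compounds shown here, only one measured step offers a guide, and that is a 9.9-fold higher number from compound 2 to compound 3 (1.00 log units; beyond the scatter) where 2,4-dichlorophenyl replaced 3,5-dimethoxyphenyl at that same kind of place. The group leaving there is a different one and carries no halogen, so this modest rise can be only partly carried over. A small shift towards a higher number is therefore expected, and the estimated step is a 1.4-fold higher number from compound 1 to compound 4 (0.14 log units; within the scatter) which would stay within the scatter. For compound 4 the expected value is 1500 nM with an estimated range from 450 nM to 5000 nM in this assay as the likely span.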

Compound 4, half-maximal inhibitory concentration: 8210 nM
For compound 4 the middle estimate is 5.5-fold (0.74 log units) below the measured one; measured number above the stated range.
By their numbers in this assay, from the lowest: compounds 2 and 1 (each within the scatter of the next); then compounds 4 and 3 (each within the scatter of the next).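

In this assay the swap of 2-fluorophenyl for 4-chlorophenyl gives a 7.6-fold higher number from compound 1 to compound 4 (0.88 log units; beyond the scatter), so this place responds even to a change that keeps the aromatic ring, the heavy-atom count and the absence of hydrogen-bond donors and acceptors. The earlier step exchanged methoxy-bearing and chlorine-bearing rings, whereas this one shows that exchanging one halogen-bearing phenyl for another can also carry the number beyond the scatter, and in both steps the group bringing chlorine gives the higher number. No measurement shown here explains this rise.

The swap changes both the halogen and its printed ring position, so the compounds shown cannot separate these two changes. Placing 4-fluorophenyl or 2-chlorophenyl at this same place on the core of compound 1 would pull them apart.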